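Moving the hydantoin onto the branch carbon of compound 3

The source may hold more compounds than are shown below. What is called first, only, known or untested is meant among the compounds shown, and "the series" means these compounds.

Of the compounds shown here, three sharing one core have been measured in an assay on membranes from Chem-1 cells for displacement of a labelled ligand from prostaglandin E2 receptor EP3 subtype (Homo sapiens), read by scintillation counting, with a stated time of 2 h; a higher number here means a weaker inhibitor, a lower number a stronger inhibitor. Compound 1 `CC(C)C(c1ccc(-c2ccc3cccc(F)c3c2)[nH]c1=O)C1SC(=O)NC1=O` gives 25 nM, compound 2 `CC(C)C(/C=C1\SC(=O)NC1=O)c1ccc(-c2ccc3cccc(F)c3c2)[nH]c1=O` gives 13 nM, and compound 3 `CC(C)C(CC1NC(=O)NC1=O)c1ccc(-c2ccc3cccc(F)c3c2)[nH]c1=O` gives 10 nM. Compound 3 holds the lowest of the three numbers: its separation from compound 2 is within the scatter, while the step of a 2.5-fold lower number from compound 1 to compound 3 (0.40 log units; beyond the scatter) lies beyond it. The step of a 1.9-fold lower number from compound 1 to compound 2 (0.28 log units; within the scatter) is within the scatter.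

Compound 4 `CC(C)C(c1ccc(-c2ccc3cccc(F)c3c2)[nH]c1=O)C1C(=O)NC(=O)N1C` differs from compound 3 in one place: 3-methyl-2,5-dioxoimidazolidin-4-yl in place of (2,5-dioxoimidazolidin-4-yl)methyl on a saturated chain carbon bound to an aromatic carbon and a saturated chain carbon. The ring thus returns to the branch carbon, as in compound 1, and one ring nitrogen carries a methyl. Among the measured compounds shown here, the step that bears most closely on this is a 2.5-fold lower number from compound 1 to compound 3 (0.40 log units; beyond the scatter), which went with the ring moving out onto a methylene; reversing that placement suggests a modest move back toward the number of compound 1, though the present ring and its methyl have no measured precedent here. For compound 4 the expected change is a 2.5-fold higher number from compound 3 to compound 4 (0.40 log units; beyond the scatter). Compound 4 is therefore estimated at 25 nM, with a range from 8 nM to 80 nM.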

Compound 4, inhibition constant in the prostaglandin E2 receptor EP3 subtype assay: 46 nM
For compound 4 the middle estimate is 1.8-fold (0.26 log units) below the measured one, within the range that was stated.
By their numbers in the prostaglandin E2 receptor EP3 subtype assay, from the lowest: compounds 3, 2, 1 and 4 (each within the scatter of the next, the first and the last beyond it).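

In the prostaglandin E2 receptor EP3 subtype assay compound 3 gives 10 nM and compound 4 gives 46 nM. Setting 3-methyl-2,5-dioxoimidazolidin-4-yl in place of (2,5-dioxoimidazolidin-4-yl)methyl produced the largest step of the series in the prostaglandin E2 receptor EP3 subtype assay (a 4.6-fold higher number from compound 3 to compound 4 (0.66 log units; beyond the scatter)). The new compound also separates from the unsaturated link of compound 2 (a 3.5-fold higher number from compound 2 to compound 4 (0.55 log units; beyond the scatter)), yet not from the other ring set directly on this carbon (a 1.8-fold higher number from compound 1 to compound 4 (0.26 log units; within the scatter)), although compound 2 likewise stays within the scatter of compound 1. In a physicochemical assay for solubility, measured as kinetic solubility, at pH 2 (a lower number here means a less soluble compound, a higher number a more soluble compound), compound 3 gives 13000 nM and compound 4 gives 13600 nM. In the physicochemical assay the same change leaves the two compounds within the scatter (a 1.0-fold higher number from compound 3 to compound 4 (0.02 log units; within the scatter)).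

Nothing measured explains the shift, and this one step changes the ring's attachment and adds the methyl together, so their shares cannot be separated. From the compounds shown here alone, how a carboxylic acid or an ethyl group on that ring nitrogen would read at this position remains open.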